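Benzoyl to Phenylcarbamoyl: What to Expect for Compound 4

The source may hold more compounds than are shown below. What is called first, only, known or untested is meant among the compounds shown, and "the series" means these compounds.

Compound 1 `COc1cc(-c2nnc(SCC(=O)c3ccccc3)n2N)cc(OC)c1OC`: 53000 nM
Compound 2 `COc1cc(-c2nnc(SCC(=O)c3ccc(Cl)cc3)n2N)cc(OC)c1OC`: 7500 nM
Compound 3 `COc1ccc(C(=O)CSc2nnc(-c3cc(OC)c(OC)c(OC)c3)n2N)cc1`: 1240 nM

In a functional assay on HCT-116 cells (Homo sapiens) for antiproliferative activity, read by MTT assay, with a stated time of 48 h (on this read-out lower numbers stand for stronger inhibition and higher numbers for weaker inhibition), compound 1 gives the highest of the three numbers. The nearest step is a 7.1-fold lower number from compound 1 to compound 2 (0.85 log units; beyond the scatter); the furthest is a 43-fold lower number from compound 1 to compound 3 (1.63 log units; beyond the scatter); the third measured step is a 6.0-fold lower number from compound 2 to compound 3 (0.78 log units; beyond the scatter). Compound 4 `COc1cc(-c2nnc(SCC(=O)Nc3ccccc3)n2N)cc(OC)c1OC` differs from compound 1 in one place: anilino in place of phenyl on a carbonyl carbon. Among the measured compounds shown here, every measured step places chloro or methoxy on the aromatic ring that compound 4 leaves untouched, and no step alters the carbonyl carbon itself, so none bears directly on this change. With nothing to lean on, no shift beyond the scatter is expected, a 1.2-fold lower number from compound 1 to compound 4 (0.07 log units; within the scatter). Compound 4 is therefore estimated at 45000 nM, with a range from 12000 nM to 150000 nM.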

Compound 4, half-maximal inhibitory concentration: 1730 nM
Compound 4: middle estimate off by 26-fold (1.42 log units), on the high side; measured number below the stated range.
By their numbers in this assay, from the lowest: compounds 3 and 4 (each within the scatter of the next); then compound 2; then compound 1.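

In this assay the carbonyl carbon proves to be a place that responds in its own right, not only the aromatic ring: anilino in place of phenyl gives a 31-fold lower number from compound 1 to compound 4 (1.49 log units; beyond the scatter) and so a large step. The unsubstituted anilino group thereby stands level with 4-methoxyphenyl, at a 1.4-fold higher number from compound 3 to compound 4 (0.14 log units; within the scatter) and within the scatter, while against 4-chlorophenyl it gives a 4.3-fold lower number from compound 2 to compound 4 (0.64 log units; beyond the scatter) and lies beyond the scatter. Nothing shown accounts for this step. On these data alone, whether chloro or methoxy on the anilino ring would change the number remains open, as does whether a benzylamino group on the carbonyl carbon would hold it.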